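Aryl swap on the shared core: compound 4 pending

This account rests on a few compounds, and the source may have more. Where it says the series, first, only, none or still open, it means among the compounds named here.

Of the compounds shown here, three of the shared core have been read in a functional assay on PC-12 cells (Rattus norvegicus) for cytotoxicity, read by MTT assay, with stated times of 2 h and 24 h, tested at 1 uM; a higher number here means a stronger effect of the compound at the concentration tested, a lower number a weaker effect. Compound 1 `CC(C)(C)c1ccc(-n2nc(-c3ccc(C(F)(F)F)cc3O)nc2-c2ccccc2O)cc1` gives 67.3%. Compound 2 `Oc1cc(C(F)(F)F)ccc1-c1nc(-c2ccccc2O)n(-c2ccc(Cl)cc2)n1` gives 68%, and compound 3 `Oc1cc(C(F)(F)F)ccc1-c1nc(-c2ccccc2O)n(-c2cccc(Cl)c2)n1` gives 72.3%. Compound 2 stands second highest of the three numbers, nearest to compound 1 and furthest from compound 3, and both gaps lie within the scatter.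

The next step goes from compound 2 to compound 4 `COc1cccc(-n2nc(-c3ccc(C(F)(F)F)cc3O)nc2-c2ccccc2O)c1`. The change: 3-methoxyphenyl in place of 4-chlorophenyl on an aromatic nitrogen. Among the measured compounds shown here, no measured step brings in a 3-methoxyphenyl group, so the steps that bear on it are the other swaps on the same aromatic nitrogen, a number 5 percentage points higher from compound 1 to compound 3 (within the scatter) and a number 4.3 percentage points higher from compound 2 to compound 3 (within the scatter), with a number 0.7 percentage points higher from compound 1 to compound 2 (within the scatter) as the remaining change on that aryl group. All three lie within the scatter, so for compound 4 no step beyond the scatter is expected in this assay. Compound 4 is therefore expected at 69%, in a range from 59% to 79%. The expected step is a number 1 percentage points higher from compound 2 to compound 4 (within the scatter).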

Compound 4, a percentage reported as activity, at one concentration (the size of the read-out at that concentration, not a potency): 68.3%
Compound 4: middle estimate off by 0.7 percentage points, on the high side, and the stated range covers the measured number.
By their numbers in this assay, from the lowest: compounds 1, 2, 4 and 3 (each within the scatter of the next).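

In this assay the aromatic nitrogen takes 3-methoxyphenyl, which brings an oxygen and a hydrogen-bond acceptor in place of the 4-chlorophenyl group, with a number 0.3 percentage points higher from compound 2 to compound 4 (within the scatter) and with a number 1 percentage points higher from compound 1 to compound 4 (within the scatter) as well, so a group with an oxygen joins the aryl groups that stay within the scatter of one another here. Methoxy in place of chloro on an aromatic carbon, read with the aryl ring otherwise unchanged, gives a number 4 percentage points lower from compound 3 to compound 4 (within the scatter) and also stays within the scatter. Nothing available explains why these swaps leave the read-out so close together.

Still open, going by these compounds, is whether an amine or a carboxylic acid on this aryl group, or a longer chain in place of methoxy, would give a step beyond the scatter in this assay and so show any dependence on this position. Replacing either hydroxyl group on the shared core, for instance with an amine, is equally unresolved.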